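The source may hold more compounds than are shown below. What is called first, only, known or untested is meant among the compounds shown, and "the series" means these compounds.

For the measured compounds named here, compound 1 `O=C(Nc1nn[nH]n1)c1cc(Cl)cc(-c2ccccc2)n1` is one of three compounds measured in a functional assay on the whole organism with Rattus norvegicus as the target, at a dose of 1 mg/kg by the oral route (on this read-out lower numbers stand for a weaker effect and higher numbers for a stronger effect at the one dose given), in which compound 1 gives 40%. Among those three, compound 1 stands second highest. Compound 2 `CCc1ccc(-c2cc(Cl)cc(C(=O)Nc3nn[nH]n3)n2)cc1` gives 49%, and the step of a number 9 percentage points higher from compound 1 to compound 2 (within the scatter) is ethyl in place of hydrogen on an aromatic carbon. Compound 3 `CCCCc1ccc(-c2cc(Cl)cc(C(=O)Nc3nn[nH]n3)n2)cc1` gives 0%; the step of a number 40 percentage points lower from compound 1 to compound 3 (beyond the scatter) is butyl in place of hydrogen on an aromatic carbon, and a number 49 percentage points lower from compound 2 to compound 3 (beyond the scatter) is ethyl in place of hydrogen on a saturated chain carbon, two bonds along the chain from an aromatic carbon.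

Compound 4 `CCCCc1cc(C(=O)Nc2nn[nH]n2)nc(-c2ccccc2)c1` is not yet measured. It differs from compound 1 in this way: butyl in place of chloro on an aromatic carbon, on an aromatic carbon of the core, opposite the ring nitrogen. Going by the values given here, no measured step puts a butyl on the core itself, so only the steps on the phenyl group can guide an expectation. There the long chain ended in a large fall, as a number 40 percentage points lower from compound 1 to compound 3 (beyond the scatter) and a number 49 percentage points lower from compound 2 to compound 3 (beyond the scatter) show, while the ethyl step stayed within the usual scatter. Because a number 40 percentage points lower from compound 1 to compound 3 (beyond the scatter) fell sharply, a butyl entering in a different place, with a chloro leaving at the same time, is expected to lower the read-out as well, though less surely. The expected step is a number 25 percentage points lower from compound 1 to compound 4 (beyond the scatter). Compound 4 is therefore estimated at 15%, with a range from 0% to 45%.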

Compound 4, a percentage reported as inhibition, in the whole organism at one dose (the size of the read-out at that dose, not a potency): 56%
For compound 4 the middle estimate is 41 percentage points below the measured one; measured number above the stated range.
By their numbers in this assay, from the lowest: compound 3; then compounds 1, 2 and 4 (each within the scatter of the next, the first and the last beyond it).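

In this assay, the place opposite the ring nitrogen accepts a butyl in place of chloro: a number 16 percentage points higher from compound 1 to compound 4 (beyond the scatter) is a modest step upward. The chloro is therefore not required for the effect at this one dose, and a butyl does not lower the read-out wherever it sits, since the same chain on the phenyl group gave a number 40 percentage points lower from compound 1 to compound 3 (beyond the scatter) and a complete loss. Nothing in the data explains why the two places differ.

On these data alone, it remains open whether the rise comes from the chloro leaving or the butyl entering, a question that a plain hydrogen at this place would help to separate. Also open, as far as these compounds go, is how a longer chain such as hexyl, or an amine, would behave at this place.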